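From 2-phenylethynyl to 2-chloroethenyl on the shared core

A few compounds are considered here, and "the series" means these few. Any claim that something is new, unique, unknown or untested is made for them only; others in the source may bear on it.

In an ADME assay on L1210/0 cells (Mus musculus) for cytotoxicity, with a stated time of 48 h (a higher number here means a weaker inhibitor, a lower number a stronger inhibitor), compound 1 `N#CSc1cn([C@H]2C[C@H](O)[C@@H](CO)O2)c(=O)[nH]c1=O` gives 78900 nM as a measured number. Compound 2 `O=c1[nH]c(=O)n([C@H]2C[C@H](O)[C@@H](CO)O2)cc1C#CCO` gives > 200000 nM, which is a limit. Compound 3 `O=c1[nH]c(=O)n([C@H]2C[C@H](O)[C@@H](CO)O2)cc1C#Cc1ccccc1` gives > 200000 nM, also only a limit. Compound 4 `O=c1[nH]c(=O)n([C@H]2C[C@H](O)[C@@H](CO)O2)cc1/C=C/Cl` carries 2-chloroethenyl in place of 2-phenylethynyl on an aromatic carbon, a change counted as 2-chloroethenyl in place of 2-phenylethynyl on an aromatic carbon here. Within the data shown here, no measured step makes this swap. The nearest are an at least 2.5-fold higher number from compound 1 to compound 2 (0.40 log units; beyond the scatter) and an at least 2.5-fold higher number from compound 1 to compound 3 (0.40 log units; beyond the scatter), where alkynyl groups replaced cyanosulfanyl, while a step that the two limits leave unreadable from compound 2 to compound 3 gives no size. With the alkynyl group gone, the expected step is an at least 2.2-fold lower number from compound 3 to compound 4 (0.34 log units; beyond the scatter), a modest one towards a lower number. Compound 4 is estimated at 90000 nM, within an expected range of 30000 nM to 200000 nM, and it may yet stay at the limit.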

Compound 4, half-maximal inhibitory concentration: > 200000 nM
Compound 4: a limit, no number (the forecaster's own chance of this, stated with the estimate: 35%); middle value at least 2.2-fold (0.34 log units) away from the limit.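

Removing the triple bond does not by itself bring a measured number at this position: 2-chloroethenyl, with its double bond, sits at the same limit as the two alkynyl groups. Putting it in place of cyanosulfanyl gives an at least 2.5-fold higher number from compound 1 to compound 4 (0.40 log units; beyond the scatter), which leaves cyanosulfanyl as the only group shown with a measured number. The steps among compounds 2, 3 and 4 cannot be read because all three stop at one limit: the limit of > 200000 nM in this assay, at which 3 of the 4 values shown sit.

On these data alone, whether an amine or a longer alkyl chain on this aromatic carbon would give a measured number stays open. So does the order of compounds 2, 3 and 4.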